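Amide nitrogen substituents in the shared core: compound 3 to compound 4

The source may hold more compounds than are shown below. What is called first, only, known or untested is meant among the compounds shown, and "the series" means these compounds.

Measured compounds:
compound 1 `CC(C)c1c(C(=O)N2CCC[C@H](c3ccccc3)C2)nn(-c2ccc(F)cc2)c1CC[C@@H](O)C[C@@H](O)CC(=O)O` — 2.1 nM
compound 2 `CC(C)c1c(C(=O)N2CCC[C@H](N3CCC4C=CC=CC4C3)C2)nn(-c2ccc(F)cc2)c1CC[C@@H](O)C[C@@H](O)CC(=O)O` — 10 nM
compound 3 `COc1ccc(CNC(=O)c2nn(-c3ccc(F)cc3)c(OC[C@@H](O)C[C@@H](O)CC(=O)O)c2C(C)C)cc1` — 12 nM

In an assay on microsomes from liver for inhibition of 3-hydroxy-3-methylglutaryl-coenzyme A reductase (Rattus norvegicus) (on this read-out higher numbers stand for weaker inhibition and lower numbers for stronger inhibition), compound 3 gives 12 nM, the highest of the three numbers. Compound 2, at 10 nM, sits within the scatter of compound 3, while compound 1, at 2.1 nM, lies beyond it with the lower number. For the measured compounds named here, the shared core carries an amide on the aromatic carbon; the only single-place step among the measured compounds is at the amide nitrogen, a 4.8-fold higher number from compound 1 to compound 2 (0.68 log units; beyond the scatter). Compound 4 `CC(C)c1c(C(=O)N(C)Cc2ccc(F)cc2)nn(-c2ccc(F)cc2)c1OC[C@@H](O)C[C@@H](O)CC(=O)O` differs from compound 3 at the same amide: (4-fluorobenzyl)(methyl)amino in place of (4-methoxybenzyl)amino on a carbonyl carbon. Going by the values given here, the step from compound 1 to compound 2 changes a piperidine ring substituent, not the benzyl group or the amide hydrogen, so it offers no direct read-across; no measured pair shows a methoxy replaced by fluorine or an amide hydrogen replaced by methyl. With nothing beyond that, the change from compound 3 to compound 4 is expected to be a 1.3-fold higher number from compound 3 to compound 4 (0.10 log units; within the scatter), which does not clear the scatter. Compound 4 is accordingly estimated at 15 nM in this assay, with a range from 5 nM to 45 nM.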

Compound 4, half-maximal inhibitory concentration: 18 nM
The estimate for compound 4 lay 1.2-fold (0.08 log units) below the measured number; measured number inside the range.
By their numbers in this assay, from the lowest: compound 1; then compounds 2, 3 and 4 (each within the scatter of the next).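

In this assay, for the compounds shown here, the first step at this amide on the shared core is a 1.5-fold higher number from compound 3 to compound 4 (0.18 log units; within the scatter), so (4-fluorobenzyl)(methyl)amino and (4-methoxybenzyl)amino cannot be told apart on a carbonyl carbon whose other neighbour is an aromatic carbon. The entering group has neither the hydrogen-bond donor nor the hydrogen-bond acceptor counted on the leaving group, so in this pair, inhibition in this assay does not depend on keeping the amide hydrogen and the methoxy group; the earlier step from compound 1 to compound 2 could not show this, as it concerned neither feature. Nothing at hand accounts for this result in terms of a measured property.

The pair changes the methoxy group and the amide hydrogen together, so a small contribution from one could be offset by the other, and the effect of each alone remains unresolved. Also open, going by these compounds, is how the number would respond to a nitrile in place of the fluorine, or to an ethyl group in place of the methyl on the amide nitrogen.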